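A few compounds are considered here, and "the series" means these few. Any claim that something is new, unique, unknown or untested is made for them only; others in the source may bear on it.

Measured in a functional assay on PC-3 cells (Homo sapiens) for antiproliferative activity, read by MTT assay, with a stated time of 72 h; on this read-out higher numbers stand for weaker inhibition and lower numbers for stronger inhibition:
- compound 1 `CCCCCCCCNC[C@@H]1OC[C@H](N)[C@@H]1O`: 13800 nM
- compound 2 `CCCCCCCCNC[C@@H]1OC[C@H](N)[C@H]1O`: 13000 nM
- compound 3 `CCCCCCCCCCNC[C@@H]1OC[C@H](N)[C@H]1O`: > 128000 nM

The entry for compound 3, > 128000 nM, is a limit and not a number. Within the data shown here, compound 1 stands level with the only other number, since a 1.1-fold lower number from compound 1 to compound 2 (0.03 log units; within the scatter). That step involves configuration alone, so it offers little guidance here. Compound 4 `CCCCCCCCCCCCCCNC[C@@H]1OC[C@H](N)[C@@H]1O` differs from compound 1 by hexyl in place of hydrogen on a saturated chain carbon, eight bonds along the chain from an amine nitrogen. Among the measured compounds shown here, the nearest precedent is the ethyl change, where an at least 9.8-fold higher number from compound 2 to compound 3 (0.99 log units; beyond the scatter). A larger group at the same place therefore leads to the expectation of a step of similar size or more in this assay, towards a higher number, and possibly only a limit. The expected step is a 7.2-fold higher number from compound 1 to compound 4 (0.86 log units; beyond the scatter). For compound 4 the estimate is 100000 nM, with an expected range of 12000 nM to 400000 nM.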

Compound 4, half-maximal inhibitory concentration: 1200 nM
Beside the measured number, compound 4's estimate is 83-fold (1.92 log units) above it, and the stated range ends above it.
By their numbers in this assay, from the lowest: compound 4; then compounds 2 and 1 (each within the scatter of the next). At a limit, above all of these: compound 3.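

In this assay hexyl in place of hydrogen on this saturated chain carbon gives a 12-fold lower number from compound 1 to compound 4 (1.06 log units; beyond the scatter) and so shows that a larger group at this place can go with stronger inhibition. The ethyl change gave an at least 9.8-fold higher number from compound 2 to compound 3 (0.99 log units; beyond the scatter) instead, so across the compounds shown, added chain at this place has no single direction. These two steps start from different configurations, yet that difference alone changed little: the fact that compounds 1 and 2 differ only in the configuration as drawn

As far as these compounds go, what a longer chain or an amine at the end of the hexyl group would do remains open. So does whether hexyl has the same effect on compound 2.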